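This account rests on a few compounds, and the source may have more. Where it says the series, first, only, none or still open, it means among the compounds named here.

Compound 2, `Cc1c(C(=O)N/N=C/c2ccc(C(=O)O)cc2)no[n+]1[O-]`, was tested in an ADME assay on J744 cells (Mus musculus) for cytotoxicity, read by MTT assay, with a stated time of 48 h; on this read-out lower numbers stand for stronger inhibition and higher numbers for weaker inhibition. In this assay compound 2 gives only a limit, > 400000 nM, not a number. Compound 1, `Cc1c(C(=O)N/N=C/c2ccc(C(F)(F)F)cc2)no[n+]1[O-]`, differs from compound 2 in having trifluoromethyl where compound 2 has carboxy. In this assay compound 1 likewise gives only a limit, > 400000 nM. The step that the two limits leave unreadable from compound 1 to compound 2 is therefore not readable, because both values sit at the limit of > 400000 nM in this assay, at which 2 of the 2 values shown sit. Compound 3, `Cc1c(C(=O)N/N=C/c2ccc(Br)cc2)no[n+]1[O-]`, is the compound still to be measured, and its change from compound 2 is bromo in place of carboxy on an aromatic carbon. Among the compounds with values here, no measured step gives a readable size for this change in this assay, since the limit of > 400000 nM in this assay, at which 2 of the 2 values shown sit, hides both values that exist. The expectation for compound 3 is therefore that this assay again reports a limit rather than a number. The step expected for compound 3 is estimated as a number no higher from compound 2 to compound 3 (the limit leaves the size open). The estimate for compound 3 is 400000 nM, within a range from 150000 nM to 1000000 nM.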

Compound 3, half-maximal inhibitory concentration: 162000 nM
The estimate for compound 3 lay 2.5-fold (0.39 log units) above the measured number; measured number inside the range.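

In this assay, a group on this aromatic carbon, para to a large group, can shift the read-out into a measurable range, which neither earlier compound showed. Bromo gives an at least 2.4-fold lower number from compound 2 to compound 3 (0.39 log units; beyond the scatter) and, against the other earlier group, an at least 2.4-fold lower number from compound 1 to compound 3 (0.39 log units; beyond the scatter), so on this read-out the change goes toward stronger inhibition. These sizes are only minimums, and the step between compound 1 and compound 2 still cannot be read, because both of those compounds stop at a limit and not at a number: the limit of > 400000 nM in this assay, at which 2 of the 3 values shown sit.

The compounds shown leave open whether this shift belongs to bromo alone or would also appear with chloro, methoxy or an amine at the same place. They also leave open how far compound 1 and compound 2 truly lie from compound 3.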